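The source may report more compounds than this note shows. Statements on the series, on what has been measured and on what is new or still open speak of the compounds shown alone.

Series notes, pyrazolylbutyl amides on the shared core. Compound 1 `COc1ccc(F)cc1N1C(=O)CSC1c1cccc(C(=O)NCCCCn2cccn2)c1` is one of two measured members; in an ADME assay on microsomes from liver (Homo sapiens) for metabolic stability, read by LC-MS, using NADPH, with a stated time of 10 min, tested at 0.1 uM (on this read-out higher numbers stand for fast clearance and lower numbers for slow clearance), compound 1 gives 421 mL.min-1.g-1. Compound 2 `C#Cc1cc(C(=O)NCCCCc2ccccc2)cc(C2SCC(=O)N2c2ccccc2OC)c1`, which carries a phenylbutyl chain in place of the pyrazolylbutyl chain and an ethynyl group on the central ring, gives in this assay 1730 mL.min-1.g-1. Compound 1 thus stands at the lower of the two numbers, and compound 2 at the higher, the gap between them falling beyond the usual scatter of this read-out.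

The next step keeps the pyrazolylbutyl amide and alters only the group on the ring nitrogen: compound 3 `Cc1ccnc(N2C(=O)CSC2c2cccc(C(=O)NCCCCn3cccn3)c2)c1`, not yet measured in this assay, differs from compound 1 in one place: 4-methylpyridin-2-yl in place of 5-fluoro-2-methoxyphenyl on an amide-type nitrogen in a ring

Among the compounds with values here, no measured pair in the set isolates this exchange, so the expectation leans on compound 1 alone. The step of a 1.4-fold lower number from compound 1 to compound 3 (0.15 log units; within the scatter) is expected to be small, on the slow side if anything, and not clearly beyond the scatter. Compound 3 is accordingly estimated at 300 mL.min-1.g-1 in this assay, with a plausible range from 110 mL.min-1.g-1 to 800 mL.min-1.g-1.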

Compound 3, intrinsic clearance in microsomes: 129 mL.min-1.g-1
Estimate against measurement, compound 3: 2.3-fold (0.37 log units) above; low and high end bracket the measured number.
By their numbers in this assay, from the lowest: compound 3; then compound 1; then compound 2.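

With the pyrazolylbutyl amide held fixed, the group on the amide-type nitrogen in the ring now gives a single-place comparison: in this assay, 4-methylpyridin-2-yl in place of 5-fluoro-2-methoxyphenyl gives a 3.3-fold lower number from compound 1 to compound 3 (0.51 log units; beyond the scatter). This position therefore affects the read-out with the chain and the rest of the shared core unchanged, and the exchange of a six-membered aromatic ring of carbon only for one with 1 hetero atom moves the number toward slow clearance. No measurement at hand bears on why the number falls.

Going by these compounds, the exchange alters the ring atoms and both substituents at once, so the share of each remains open; a plain phenyl or an unsubstituted pyridyl on the pyrazolylbutyl amide would begin to separate them. Also open, on these data alone, is whether 4-methylpyridin-2-yl gives a similar step alongside the phenylbutyl chain and the ethynyl group of compound 2, and how an amine or a carboxylic acid at this position would read in this assay.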